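Methyl on the fused ring: effect on growth inhibition

The source may hold more compounds than are shown below. What is called first, only, known or untested is meant among the compounds shown, and "the series" means these compounds.

Measured compounds:
Compound 1 `Cc1cc(-c2nc3sc(C)cn3c2/C=N/NC(=N)N)c(C)s1` gives 3720 nM in a functional assay on cells (Cancer cell lines, Homo sapiens) for inhibition; a higher number here means a weaker inhibitor of growth, a lower number a stronger inhibitor of growth.
Compound 3 `Cc1cc(-c2nc3sccn3c2/C=N/NC(=N)N)c(C)s1` gives 15500 nM in this assay.
Compound 2 `N=C(N)N/N=C/c1c(-c2cccs2)nc2sccn12` gives 9770 nM in this assay.

Compound 3 and compound 1 share a core and differ in one place: methyl in place of hydrogen on an aromatic carbon. This change is accompanied by a 4.2-fold lower number from compound 3 to compound 1 (0.62 log units; beyond the scatter), a step that lies beyond the scatter of the assay.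

Compound 2 differs from compound 3 in the group on the two-ring core: thiophen-2-yl in place of 2,5-dimethylthiophen-3-yl on an aromatic carbon. Here a 1.6-fold higher number from compound 2 to compound 3 (0.20 log units; within the scatter), a step that stays within the scatter, so nothing can be said about an order between these two compounds.

Compound 4 `Cc1cn2c(/C=N/NC(=N)N)c(-c3cccs3)nc2s1` has not yet been measured. It stands to compound 2 as compound 1 stands to compound 3: methyl in place of hydrogen on an aromatic carbon. The two place descriptions agree word for word, so this is the same change, made on a core that carries thiophen-2-yl instead of 2,5-dimethylthiophen-3-yl.

Going by the values given here, only one measured pair carries this change, and the two cores are close in this assay. On that basis, the step from compound 2 to compound 4 is expected to resemble the step from compound 3 to compound 1, with the expectation worded as a 3.6-fold lower number from compound 2 to compound 4 (0.56 log units; beyond the scatter). For compound 4 the expected value in this assay is 2700 nM, within a range from 1200 nM to 6500 nM, the width reflecting that the transfer rests on a single precedent.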

Compound 4, concentration for 50% growth inhibition: 2570 nM
Compound 4: middle estimate off by 1.1-fold (0.02 log units), on the high side; low and high end bracket the measured number.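

In this assay, methyl in place of hydrogen on an aromatic carbon, next to the ring sulfur, comes with a 3.8-fold lower number from compound 2 to compound 4 (0.58 log units; beyond the scatter), and this step does not differ from the one seen on the core bearing 2,5-dimethylthiophen-3-yl: the same change on two cores in this assay, a 4.2-fold lower number (0.62 log units; beyond the scatter) from compound 3 to compound 1 and a 3.8-fold lower number (0.58 log units; beyond the scatter) from compound 2 to compound 4, 1.1-fold (0.04 log units) apart, within the scatter of two such steps
The exchange of the two thiophene groups gives a 1.4-fold lower number from compound 1 to compound 4 (0.16 log units; within the scatter), so no order can be set between compound 1 and compound 4, and this exchange reads the same with hydrogen or with methyl at that place: the same change on two cores in this assay, a 1.6-fold higher number (0.20 log units; within the scatter) from compound 2 to compound 3 and a 1.4-fold higher number (0.16 log units; within the scatter) from compound 4 to compound 1, 1.1-fold (0.04 log units) apart, within the scatter of two such steps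
The change therefore carried over between these two cores, but that rests on just two pairs with closely related thiophene groups, in a single cell growth read-out, and it neither establishes a rule for other cores nor explains why methyl goes with the lower numbers.

The compounds shown leave open whether ethyl, a longer chain or a chlorine atom at the same place would extend, keep or lose the step seen with methyl. Also open, as far as these compounds go, is whether the step would persist with phenyl in place of the thiophene groups, or with an amine in place of the side chain shared by all four compounds.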